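A single substituent swap at the top of the range

The source may report more compounds than this note shows. Statements on the series, on what has been measured and on what is new or still open speak of the compounds shown alone.

In an ADME assay on Vero cells (Chlorocebus sabaeus) for cytotoxicity, with a stated time of 72 h (on this read-out lower numbers stand for stronger inhibition and higher numbers for weaker inhibition), compound 1 `O=[N+]([O-])c1cn2c(n1)OCC(COCc1ccc(OC(F)(F)F)cc1)C2` gives 46000 nM and compound 2 `O=[N+]([O-])c1cn2c(n1)OCC(COCc1ccc(OCc3ccccc3)cc1)C2` gives 113000 nM. Among the compounds with values here, the one measured step between compounds differing in a single place is a 2.5-fold higher number from compound 1 to compound 2 (0.39 log units; beyond the scatter). Compound 3 `O=[N+]([O-])c1cn2c(n1)OCC(COCc1ccc(-c3ccc(OC(F)(F)F)cc3)cc1)C2` gives > 128000 nM, which is a limit of the assay rather than a number. Compound 3 therefore stands at the limit of > 128000 nM in this assay, at which 1 of the 3 values shown sits. Compound 4 `O=[N+]([O-])c1cn2c(n1)OCC(COCc1ccc(-c3ccc(C(F)(F)F)cc3)cc1)C2` differs from it by trifluoromethyl in place of trifluoromethoxy on an aromatic carbon. Within the data shown here, no measured step covers this replacement, and the step from compound 1 to compound 2 concerns a different group, so no shift beyond the scatter is expected. Compound 4 is expected to give 150000 nM, with a range of 60000 nM to 400000 nM. The expected step is a step that the limit leaves unreadable from compound 3 to compound 4.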

Compound 4, half-maximal inhibitory concentration: 38000 nM
For compound 4 the middle estimate is 3.9-fold (0.60 log units) above the measured one, and the stated range ends above it.
By their numbers in this assay, from the lowest: compounds 4 and 1 (each within the scatter of the next); then compound 2. At a limit, above all of these: compound 3.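

The swap of trifluoromethoxy for trifluoromethyl on this aromatic carbon, para to a large group, gives an at least 3.3-fold lower number from compound 3 to compound 4 (0.52 log units; beyond the scatter), so a change of this size alone moves the number in this assay. Compound 3 is held at a limit, not a number: the limit of > 128000 nM in this assay, at which 1 of the 4 values shown sits. 4-(Trifluoromethyl)phenyl in place of benzyloxy gives a 3.0-fold lower number from compound 2 to compound 4 (0.47 log units; beyond the scatter), whereas in place of trifluoromethoxy it gives a 1.2-fold lower number from compound 1 to compound 4 (0.08 log units; within the scatter).

Going by these compounds, what a nitrile or an amine on this aromatic carbon would give stays open. So does how far compound 3 lies beyond its limit.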